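The source may hold more compounds than are shown below. What is called first, only, known or untested is meant among the compounds shown, and "the series" means these compounds.

Compound 1, `N#Cc1cc(Cl)ccc1NC(=O)c1ccc2cccnc2c1O`, gives 280 nM.
Compound 2, `O=C(Nc1ccc(Br)c(Cl)c1)c1cc(F)ccc1O`, gives 1250 nM.
Compound 3, `O=C(Nc1ccc(Cl)cc1)c1ccc2cccnc2c1O`, gives 380 nM.

These three compounds were measured in a functional assay on NALM-6 cells (Homo sapiens) for cytotoxicity, read by luminescence and CellTiter-Glo, with a stated time of 3 days; a lower number here means a stronger inhibitor, a higher number a weaker inhibitor. Among them, compound 2 stands at the highest number: compound 3 gives 380 nM and compound 1 gives 280 nM, and both of those gaps to compound 2 lie beyond the scatter, so compound 2 is the weakest of the three. Going by the values given here, compound 1 and compound 3 share a core that differs from that of compound 2, and the one measured step between them, a 1.4-fold higher number from compound 1 to compound 3 (0.13 log units; within the scatter), concerns the removal of a nitrile and tells nothing about swapping one halogen for another.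

Compound 4, `O=C(Nc1ccc(Cl)c(Cl)c1)c1cc(F)ccc1O`, is compound 2 with one change: chloro in place of bromo on an aromatic carbon. Among the compounds with values here, no measured step bears on this kind of exchange, so the expectation rests only on the fact that the group leaving and the group entering are each a single halogen atom of the same kind of place. The step from compound 2 to compound 4 is therefore expected to stay within the scatter, as a 1.0-fold higher number from compound 2 to compound 4 (0.02 log units; within the scatter). Compound 4 is estimated to give 1300 nM in this assay, with a range from 600 nM to 2900 nM.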

Compound 4, half-maximal inhibitory concentration: 1370 nM
For compound 4 the middle estimate is 1.1-fold (0.02 log units) below the measured one; the range from low to high includes it.
By their numbers in this assay, from the lowest: compounds 1 and 3 (each within the scatter of the next); then compounds 2 and 4 (each within the scatter of the next).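

In this assay, chloro in place of bromo on an aromatic carbon, ortho to a chloro group and para to a large group, gives a 1.1-fold higher number from compound 2 to compound 4 (0.04 log units; within the scatter) and so leaves the number effectively unchanged. Going by these compounds alone, the earlier compounds offered only the loss of a nitrile on a different core, so this is the first direct look at one halogen exchanged for another, and at this place on the core of compound 2 the assay does not tell bromo and chloro apart. No measurement shown here offers a reason for this result.

This single exchange swaps one halogen atom for another, so it leaves open how far the number can move at this place when the entering group is of another kind, such as a methyl group, a methoxy group or an amine. It is also seen on one core only, and whether chloro and bromo would give matching numbers on the core of compound 1 remains an open question.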